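Urea to benzamide on a pyrazole-pyridine scaffold

A few compounds are considered here, and "the series" means these few. Any claim that something is new, unique, unknown or untested is made for them only; others in the source may bear on it.

Measured so far in a functional assay on OVCAR-8 cells (Homo sapiens) for inhibition, read by sulforhodamine B assay, with a stated time of 48 h; on this read-out higher numbers stand for weaker inhibition of growth and lower numbers for stronger inhibition of growth:
- compound 1, `O=C(Nc1cccc(-n2cc(-c3ccncc3)c(-c3ccc(Cl)c(O)c3)n2)c1)Nc1ccc(Cl)c(Cl)c1`: > 32500 nM, a limit of the assay rather than a number
- compound 2, `O=C(Nc1cccc(-n2cc(-c3ccncc3)c(-c3ccc(Cl)c(O)c3)n2)c1)Nc1cc(C(F)(F)F)cc(C(F)(F)F)c1`: 5920 nM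
- compound 3, `COc1cc(-c2nn(-c3cccc(NC(=O)Nc4cccc(C(F)(F)F)c4)c3)cc2-c2ccncc2)ccc1Cl`: 2700 nM

Of the two numbers in hand, compound 3 has the lower one, and its nearest neighbour, compound 2, sits above it by a gap beyond the scatter. For compound 1 only a limit is known, (the limit of > 32500 nM in this assay, at which 1 of the 3 values shown sits).

Compound 4, `COc1cc(-c2nn(-c3cccc(NC(=O)c4ccccc4)c3)cc2-c2ccncc2)ccc1Cl`, has not yet been measured. It differs from compound 3 in one place: phenyl in place of (3-(trifluoromethyl)phenyl)amino on a carbonyl carbon. The urea that all three measured compounds share is thus replaced by a benzamide, and the trifluoromethyl group is gone with it.

Among the compounds with values here, no step between two measured compounds isolates this change, so the expectation rests on compound 3 alone. The author expects a step toward weaker growth inhibition in this assay, of the size a 3.7-fold higher number from compound 3 to compound 4 (0.57 log units; beyond the scatter), and estimates compound 4 at 10000 nM, within the range 3000 nM to 32500 nM.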

Compound 4, concentration for total growth inhibition: > 100000 nM
Compound 4: a limit, no number; the forecaster's own chance of this, stated with the estimate: 30%; middle value at least 10-fold (1.00 log units) from the limit.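

The read-out of compound 4 in this assay is a limit of the assay, not a number: the limit of > 100000 nM in this assay, at which 1 of the 4 values shown sits. Placing phenyl instead of (3-(trifluoromethyl)phenyl)amino on the carbonyl carbon gives an at least 37-fold higher number from compound 3 to compound 4 (1.56 log units; beyond the scatter), the first change in a single place among these compounds. Within the data shown here, all the earlier compounds carried the urea, so they could say nothing about this position, whereas this one change shows that growth inhibition in this assay can be lost almost entirely there.

The step removes the amino nitrogen and the trifluoromethyl group together, and the compounds shown cannot separate the two. Going by these compounds, it remains open whether a benzamide carrying trifluoromethyl on its phenyl ring, or a carbamate or sulfonamide in place of the urea, would recover growth inhibition.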